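This account rests on a few compounds, and the source may have more. Where it says the series, first, only, none or still open, it means among the compounds named here.

Compound 1 `Nc1ccccc1NC(=O)c1ccc(COc2ccc(Br)cc2)cc1`: > 32000 nM
Compound 2 `Nc1ccccc1NC(=O)c1ccc(COc2ccc(Cl)cc2)cc1`: 17300 nM
Compound 3 `Nc1ccccc1NC(=O)c1ccc(COc2ccccc2)cc1`: 4890 nM

These values come from a functional assay on HCT-116 cells (Homo sapiens) for antiproliferative activity, read by CCK-8 assay, with a stated time of 72 h; a lower number here means a stronger inhibitor, a higher number a weaker inhibitor. For compound 1, > 32000 nM is a limit of the assay and not a number. Of the two actual numbers, the lower belongs to compound 3 at 4890 nM, and the nearest is compound 2 at 17300 nM.

Compound 4 `Cc1ccc(OCc2ccc(C(=O)Nc3ccccc3N)cc2)cc1` differs from compound 3 by one change: methyl in place of hydrogen on an aromatic carbon. This is methyl in place of hydrogen on an aromatic carbon, para to a large group. The measured steps that bear on it exchange a halogen for hydrogen at that same place: a 3.5-fold lower number from compound 2 to compound 3 (0.55 log units; beyond the scatter) and an at least 6.5-fold lower number from compound 1 to compound 3 (0.81 log units; beyond the scatter). Read backwards, both show the number rising when hydrogen gives way to a halogen, but no methyl compound has been measured. Within the data shown here, a modest rise in this assay is therefore expected, towards weaker inhibition, no larger than the step seen with the chloro compound. The expected change is a 2.2-fold higher number from compound 3 to compound 4 (0.35 log units; beyond the scatter). For compound 4 the estimated value is 11000 nM, with an expected range of 4500 nM to 27000 nM.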

Compound 4, half-maximal inhibitory concentration: 4860 nM
The estimate for compound 4 lay 2.3-fold (0.35 log units) above the measured number; the measured number falls inside the stated range.
By their numbers in this assay, from the lowest: compounds 4 and 3 (each within the scatter of the next); then compound 2. At a limit, above all of these: compound 1.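

In this assay, methyl in place of hydrogen on this aromatic carbon gives a 1.0-fold lower number from compound 3 to compound 4 (0.00 log units; within the scatter), so a substituent at this place does not by itself bring the rise seen with the halogens. Measured against the chloro compound, methyl gives a 3.6-fold lower number from compound 2 to compound 4 (0.55 log units; beyond the scatter), which ties that rise to chloro and bromo among the groups shown, rather than to every group here. Compound 1 stands at a limit of the assay and not at a number, so the step to methyl, an at least 6.5-fold lower number from compound 1 to compound 4 (0.81 log units; beyond the scatter), is only a floor: the limit of > 32000 nM in this assay, at which 1 of the 4 values shown sits.

The compounds shown do not tell why methyl and the two halogens part, and one methyl group cannot define how much room this place allows. On these data alone, how an amine, a methoxy group, a carboxylic acid or a longer chain would read here remains open.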